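Methoxy for methyl: a step beyond the measured set

The source may report more compounds than this note shows. Statements on the series, on what has been measured and on what is new or still open speak of the compounds shown alone.

Of the compounds shown here, three have been measured in a functional assay on the whole organism (strain Wistar albino) for inhibition, with Rattus norvegicus as the target, read by paw edema, with stated times of 1 h and 2 h, at a dose of 0.32 mmol/kg by the intraperitoneal route; on this read-out higher numbers stand for more inhibition at the one dose given (going by the name of the read-out) and lower numbers for less inhibition. Compound 1 `COc1ccc(-c2nn(-c3ccc(Cl)cc3)cc2-c2cc(-c3ccc(Cl)cc3)[nH]c2-c2ccc(OC)cc2)cc1` gives 10.5%. Compound 2 `Cc1ccc(-c2nn(-c3ccc(S(N)(=O)=O)cc3)cc2-c2cc(-c3ccc(Cl)cc3)[nH]c2-c2ccc(F)cc2)cc1` gives 75.4%. Among the compounds with values here, compound 3 `COc1ccc(-c2[nH]c(-c3ccc(Cl)cc3)cc2-c2cn(-c3ccc(S(N)(=O)=O)cc3)nc2-c2ccc(C)cc2)cc1` gives 49.7%, which places it second highest of the three: the one measured step, a number 25.7 percentage points lower from compound 2 to compound 3 (beyond the scatter), shows how far it sits under compound 2, and compound 1 lies well under compound 3 without a single-place step connecting the two.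

Compound 4 `COc1ccc(-c2nn(-c3ccc(S(N)(=O)=O)cc3)cc2-c2cc(-c3ccc(Cl)cc3)[nH]c2-c2ccc(OC)cc2)cc1` differs from compound 3 in one place: methoxy in place of methyl on an aromatic carbon. Put one bond further out, the 4-methylphenyl becomes a 4-methoxyphenyl. Within the data shown here, no measured step shows this exact exchange. Among the measured compounds shown here, the only step touching a methoxy entering, a number 25.7 percentage points lower from compound 2 to compound 3 (beyond the scatter), concerns methoxy in place of fluoro on the other ring and was a modest drop, so it bears on compound 4 only loosely. Compound 1, with methoxy on both rings, gives the lowest number of the three, but it also lacks the sulfonamide, so its low number cannot be read as a step. An estimate for compound 4 is therefore a small drop, a number 9.7 percentage points lower from compound 3 to compound 4 (within the scatter), giving about 40%, between 22% and 58%.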

Compound 4, a percentage reported as inhibition, in the whole organism at one dose (the size of the read-out at that dose, not a potency): 48.2%
Compound 4: middle estimate off by 8.2 percentage points, on the low side; low and high end bracket the measured number.
By their numbers in this assay, from the lowest: compound 1; then compounds 4 and 3 (each within the scatter of the next); then compound 2.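

In this assay, within the data shown here, exchanging 4-methylphenyl for 4-methoxyphenyl gives a number 1.5 percentage points lower from compound 3 to compound 4 (within the scatter) and so provides the first direct reading of this change at this position: with the sulfamoyl group present, methoxy and methyl cannot be told apart in this test. The second step, sulfamoyl in place of chloro, gives a number 37.7 percentage points higher from compound 1 to compound 4 (beyond the scatter) and is large, so the low number of compound 1 can now be tied to a single-place change rather than merely noted across several differences. No measurement given here explains either step.

The compounds shown leave open whether a longer chain such as ethoxy, or an amine or a hydroxyl, would hold the number at this position. They also leave open whether the methyl-to-methoxy result would carry over to a compound without the sulfamoyl group.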